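Swapping Methyl and Nitro on a Nucleoside Transporter Inhibitor

The compounds below may be only part of what the source reports. "The series", "measured", "known", "first", "only" and "open" are said of these compounds alone.

Measured compounds:
compound 1 `O=[N+]([O-])c1ccc(CNc2ncnc3c2ncn3[C@@H]2O[C@H](CO)[C@@H](O)[C@H]2O)c(Cl)c1` — 347 nM
compound 2 `Cc1cc(CNc2ncnc3c2ncn3[C@@H]2O[C@H](CO)[C@@H](O)[C@H]2O)ccc1[N+](=O)[O-]` — 87.1 nM

Both compounds were tested in an assay on isolated protein for binding affinity to Equilibrative nucleoside transporter 1 (Homo sapiens); a lower number here means a stronger inhibitor, a higher number a weaker inhibitor. Within the data shown here, compound 2 holds the lowest of the two numbers; the only measured step, a 4.0-fold lower number from compound 1 to compound 2 (0.60 log units; beyond the scatter), exchanged 2-chloro-4-nitrophenyl for 3-methyl-4-nitrophenyl on a saturated chain carbon bound to a nitrogen on an aromatic ring, and it was modest but beyond the scatter.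

Compound 3 `Cc1ccc(CNc2ncnc3c2ncn3[C@@H]2O[C@H](CO)[C@@H](O)[C@H]2O)cc1[N+](=O)[O-]` is the next step: 4-methyl-3-nitrophenyl in place of 3-methyl-4-nitrophenyl on a saturated chain carbon bound to a nitrogen on an aromatic ring. The same atoms are present, joined differently. Among the measured compounds shown here, no measured step rearranges the methyl and nitro groups in this way, so the one known step gives only indirect guidance. Compound 3 is therefore expected to stay close to compound 2 in this assay, with a step of a 1.7-fold higher number from compound 2 to compound 3 (0.24 log units; within the scatter) that may not exceed the scatter. The estimate for compound 3 is 150 nM, within a range of 40 nM to 600 nM.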

Compound 3, half-maximal inhibitory concentration: 1170 nM
Compound 3: middle estimate off by 7.8-fold (0.89 log units), on the low side, and the stated range ends below it.
By their numbers in this assay, from the lowest: compound 2; then compound 1; then compound 3.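

In this assay, among these compounds, the exchange of 3-methyl-4-nitrophenyl for 4-methyl-3-nitrophenyl on the saturated chain carbon bound to a nitrogen on an aromatic ring gave a 13-fold higher number from compound 2 to compound 3 (1.13 log units; beyond the scatter) and so was a large step, although the atoms stayed the same and the only earlier step was modest. The 4-methyl-3-nitrophenyl group also compares poorly with 2-chloro-4-nitrophenyl, with a 3.4-fold higher number from compound 1 to compound 3 (0.53 log units; beyond the scatter) in this comparison, which leaves compound 3 with the highest number of the three. Nothing available explains why the two arrangements differ.

The compounds shown do not separate the part played by the nitro group from that of the methyl group, as neither moves alone. From the compounds shown here alone, whether a nitrile or a carboxylic acid in place of the nitro group of compound 2 would keep the low number also remains open.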